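Cytotoxicity notes on a diphenyl-triazine piperazine amide series

A few compounds are considered here, and "the series" means these few. Any claim that something is new, unique, unknown or untested is made for them only; others in the source may bear on it.

Measured so far in an ADME assay on NIH3T3 cells (Mus musculus) for cytotoxicity, read by MTT assay, with a stated time of 24 h; on this read-out higher numbers stand for weaker inhibition and lower numbers for stronger inhibition:
compound 1, `O=C(CN1CCN(c2ccccc2Cl)CC1)N1CCN(c2nnc(-c3ccccc3)c(-c3ccccc3)n2)CC1`, gives 350000 nM
compound 2, `COc1cccc(N2CCN(CC(=O)N3CCN(c4nnc(-c5ccccc5)c(-c5ccccc5)n4)CC3)CC2)c1`, gives 361000 nM
compound 3, `COc1ccc(-c2nnc(N3CCN(C(=O)CN4CCN(c5ccccc5Cl)CC4)CC3)nc2-c2ccc(OC)cc2)cc1`, gives > 814000 nM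

Compound 1 and compound 2 share one core and differ only by 3-methoxyphenyl in place of 2-chlorophenyl on an amine nitrogen in a ring. The step of a 1.0-fold higher number from compound 1 to compound 2 (0.01 log units; within the scatter); the two values are within the scatter of each other, so no order between compound 1 and compound 2 is claimed.

For compound 3 the value in this assay is a limit of the assay and not a number. It is the limit given by the limit of > 814000 nM in this assay, at which 1 of the 3 values shown sits. The difference between the core of compound 3 and the core of compound 1 is not broken down here.

Compound 4, `COc1ccc(-c2nnc(N3CCN(C(=O)CN4CCN(c5cccc(OC)c5)CC4)CC3)nc2-c2ccc(OC)cc2)cc1`, is not yet measured in this assay. It stands to compound 3 as compound 2 stands to compound 1: the change is 3-methoxyphenyl in place of 2-chlorophenyl on an amine nitrogen in a ring, at a place described in the same words as for the earlier pair, so it is the same change.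

Expectation: since the same change gave the step of a 1.0-fold higher number from compound 1 to compound 2 (0.01 log units; within the scatter), the step that the limit leaves unreadable from compound 3 to compound 4 is expected to be of similar, small size. Compound 4 is therefore estimated at 900000 nM in this assay, with a range from 500000 nM to 2000000 nM, and most likely the assay will again report only a limit rather than a number.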

Compound 4, half-maximal inhibitory concentration: > 821000 nM
Compound 4: a limit, no number; the forecaster's own chance of this, stated with the estimate: 80%; the middle value is on the limit's open side.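

In this assay, going by these compounds alone, compound 3 and compound 4 each give only a limit of the assay and not a number, so no step between them can be read. The compounds shown leave open what numerical value either compound would have, and so whether 3-methoxyphenyl in place of 2-chlorophenyl has any effect on the core of compound 3.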